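A few compounds are considered here, and "the series" means these few. Any claim that something is new, unique, unknown or untested is made for them only; others in the source may bear on it.

Measured so far in a physicochemical assay for lipophilicity, at pH 7.4; on this read-out higher numbers stand for higher lipophilicity and lower numbers for lower lipophilicity:
Compound 1 `Cc1cc(/C=C/C#N)cc(C)c1Oc1cc(Nc2ccc(C#N)cc2)c(N)cc1C(N)=O` gives 3.53
Compound 2 `Cc1cc(CCC#N)cc(C)c1Oc1cc(Nc2ccc(C#N)cc2)c(N)cc1C(F)(F)F` gives > 5 as a limit of the assay
Compound 3 `COC(=O)c1cc(N)c(Nc2ccc(C#N)cc2)cc1Oc1c(C)cc(CCC#N)cc1C` gives 4.15

Of the two true numbers, compound 3 holds the higher, and compound 1 lies lower by more than the scatter. For compound 2 there is only the limit of > 5 in this assay, at which 1 of the 3 values shown sits, and no number.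

Compound 4 `Cc1cc(CCC#N)cc(C)c1Oc1cc(Nc2ccc(C#N)cc2)c(N)cc1C(N)=O` is still unmeasured. It differs from compound 3 by amino in place of methoxy on a carbonyl carbon, or methoxycarbonyl to carbamoyl when cut one bond further out.

For the measured compounds named here, one measured step bears on this indirectly: a number at least 0.85 log units lower from compound 2 to compound 3 (beyond the scatter), with methoxycarbonyl in place of trifluoromethyl on an aromatic carbon. It starts from a limit, so it gives only a bound. Compound 1 also carries carbamoyl and reads 3.53 in this assay, which points the same way. A modest step downward, beyond the scatter, is therefore expected.

The expected change is a number 0.75 log units lower from compound 3 to compound 4 (beyond the scatter) in this estimate. Compound 4 is expected to read 3.4, with an estimated range of 3 to 3.8 when measured.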

Compound 4, partition coefficient: 2.65
Beside the measured number, compound 4's estimate is 0.75 log units above it; the whole stated range lies above it.
By their numbers in this assay, from the lowest: compound 4; then compound 1; then compound 3. At a limit, above all of these: compound 2.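

In this assay, for the compounds shown here, amino in place of methoxy on this carbonyl carbon gives a number 1.50 log units lower from compound 3 to compound 4 (beyond the scatter), the first direct reading of this change, and it is a large step. Starting from a limit of the assay, carbamoyl in place of trifluoromethyl gives a number at least 2.35 log units lower from compound 2 to compound 4 (beyond the scatter), which is a bound only: the limit of > 5 in this assay, at which 1 of the 4 values shown sits. With carbamoyl held in place, 2-cyanoethyl in place of 2-cyanoethenyl gives a number 0.88 log units lower from compound 1 to compound 4 (beyond the scatter), which shows that this read-out also moves with a change made away from the carbonyl carbon.

The compounds shown leave open how a carboxylic acid or an N-methyl carboxamide on this aromatic carbon would read in this assay. They also leave open whether amino in place of methoxy gives a step of similar size when the 2-cyanoethenyl chain is present.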